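The source may hold more compounds than are shown below. What is called first, only, known or untested is meant among the compounds shown, and "the series" means these compounds.

Measured in an ADME assay on MDBK cells (Bos taurus) for cytotoxicity; on this read-out lower numbers stand for higher toxicity in this test and higher numbers for lower toxicity in this test:
compound 1 `Fc1cccc(F)c1Cn1ccc2nc(-c3c(F)cccc3F)nc-2c1` gives > 100000 nM, a limit of the assay.
compound 2 `Fc1cccc(F)c1Cn1c(-c2c(F)cccc2F)nc2cnccc21` gives > 100000 nM, a limit of the assay.
compound 3 `COc1ccc(Cn2ccc3nc(-c4ccccc4)nc-3c2)cc1` gives > 100000 nM, a limit of the assay.

Compound 3 thus stands at the top of what this assay reports, and it is not alone there: the limit of > 100000 nM in this assay, at which 3 of the 3 values shown sit. Among the compounds with values here, no step between measured compounds is available, so nothing here shows how a change on the saturated chain carbon bound to an aromatic nitrogen moves the half-maximal cytotoxic concentration. Compound 4 `N#Cc1cccc(Cn2ccc3nc(-c4ccccc4)nc-3c2)c1` differs from compound 3 by 3-cyanophenyl in place of 4-methoxyphenyl on a saturated chain carbon bound to an aromatic nitrogen. The step from compound 3 to compound 4 is expected to be none beyond the usual scatter, a number no higher from compound 3 to compound 4 (the limit leaves the size open). For compound 4 the estimate is 100000 nM, within 40000 nM to 250000 nM, most likely again reported only as a limit.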

Compound 4, half-maximal cytotoxic concentration: > 100000 nM
Compound 4 gave a limit, no number; the forecaster's own chance of this, stated with the estimate: 80%; the middle value lies on the limit itself.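

Compound 3 and compound 4 both end at a limit, so no step between them can be read: the limit of > 100000 nM in this assay, at which 4 of the 4 values shown sit.

The compounds shown leave open what actual half-maximal cytotoxic concentration any of them has, and whether a change on the saturated chain carbon bound to an aromatic nitrogen moves it.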